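Dimethylsulfamoyl replaces (methylsulfanyl)carbonyl on the ring amine

The source may report more compounds than this note shows. Statements on the series, on what has been measured and on what is new or still open speak of the compounds shown alone.

In a functional assay on CHO-K1 cells for agonist activity at Glucose-dependent insulinotropic receptor (Homo sapiens), read by a luciferase reporter, with a stated time of 5 h (on this read-out lower numbers stand for an effect already at smaller amounts and higher numbers for an effect only at larger amounts of compound), compound 3 `CSC(=O)N1CCC(Oc2ncnc3c2CCN3c2ccc(S(C)(=O)=O)cc2F)CC1` gives 251 nM, the second highest of three numbers. Compound 1 `COC(=O)N1CCC(Oc2ncnc3c2CCN3c2ccc(S(C)(=O)=O)cc2F)CC1` gives 316 nM, and the step of a 1.3-fold lower number from compound 1 to compound 3 (0.10 log units; within the scatter) stays within the scatter. Compound 2 `CCCCOC(=O)N1CCC(Oc2ncnc3c2CCN3c2ccc(S(C)(=O)=O)cc2F)CC1` gives 50.1 nM; the steps of a 6.3-fold lower number from compound 1 to compound 2 (0.80 log units; beyond the scatter) and a 5.0-fold higher number from compound 2 to compound 3 (0.70 log units; beyond the scatter) show that a longer chain on the oxygen bound to the carbonyl group brings a modest gain. Compound 4 `CN(C)S(=O)(=O)N1CCC(Oc2ncnc3c2CCN3c2ccc(S(C)(=O)=O)cc2F)CC1` carries dimethylsulfamoyl in place of (methylsulfanyl)carbonyl on an amine nitrogen in a ring. For the measured compounds named here, no measured pair exchanges the carbonyl group itself for a sulfonyl group, so the nearest guide is the small step of a 1.3-fold lower number from compound 1 to compound 3 (0.10 log units; within the scatter), where only the group on the carbonyl carbon changed. The expected step of a 1.2-fold higher number from compound 3 to compound 4 (0.08 log units; within the scatter) is therefore small. Compound 4 is estimated at 300 nM, ranging from 100 nM to 1000 nM.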

Compound 4, half-maximal effective concentration: 398 nM
For compound 4 the middle estimate is 1.3-fold (0.12 log units) below the measured one, and the stated range covers the measured number.
By their numbers in this assay, from the lowest: compound 2; then compounds 3, 1 and 4 (each within the scatter of the next).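

With dimethylsulfamoyl on the amine nitrogen in the ring, the data show a 1.6-fold higher number from compound 3 to compound 4 (0.20 log units; within the scatter) and a 1.3-fold higher number from compound 1 to compound 4 (0.10 log units; within the scatter) while the carbonyl of the earlier groups is gone, so a carbonyl at this position is not needed to keep this level of effect. Compound 2 stays apart, with a 7.9-fold higher number from compound 2 to compound 4 (0.90 log units; beyond the scatter) on replacing butoxycarbonyl, so the butoxycarbonyl group remains the only one here that moves the number beyond the scatter. No measurement given here explains these results.

From the compounds shown here alone, it remains open whether a longer chain on the sulfamoyl nitrogen, as in dibutylsulfamoyl, would bring a similar gain. Going by these compounds, how a butylsulfonyl group or a butylcarbamoyl group would compare at this amine is also open.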